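Hydroxy addition on the fused ring across two core variants

The source may report more compounds than this note shows. Statements on the series, on what has been measured and on what is new or still open speak of the compounds shown alone.

Measured compounds in a functional assay on CCRF-CEM cells (Homo sapiens) for cytotoxicity; a lower number here means a stronger inhibitor, a higher number a weaker inhibitor:
compound 1, `Oc1ccc(-c2cncc(-c3cc4ccccc4[nH]3)c2)cc1`, 4670 nM
compound 2, `Oc1ccc(-c2cncc(-c3cc4cc(O)ccc4[nH]3)c2)cc1`, 14500 nM
compound 3, `CN(C)CCCOc1ccc(-c2cncc(-c3cc4ccccc4n3CCN(C)C)c2)cc1`, 3720 nM

Compound 1 and compound 2 differ in one place: hydroxy in place of hydrogen on an aromatic carbon. This change gave a 3.1-fold higher number from compound 1 to compound 2 (0.49 log units; beyond the scatter) in this assay. Compound 3 stands at 3720 nM in this assay, and its distance from compound 1 is within the scatter, so no order between the two can be claimed. How the core of compound 3 differs from the core of compound 1 is not broken down here.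

Compound 4, `CN(C)CCCOc1ccc(-c2cncc(-c3cc4cc(O)ccc4n3CCN(C)C)c2)cc1`, is not yet measured. It differs from compound 3 in one place: hydroxy in place of hydrogen on an aromatic carbon. The place is the same, word for word, as in the change from compound 1 to compound 2, so the two changes are the same change on two cores.

The expected step in this assay rests on the single earlier occurrence, because a 3.1-fold higher number from compound 1 to compound 2 (0.49 log units; beyond the scatter) was the outcome on the core of compound 1. A step of similar size from compound 3 is expected, a 3.0-fold higher number from compound 3 to compound 4 (0.47 log units; beyond the scatter). Among the measured compounds shown here, compound 4 is therefore estimated at 11000 nM, with a range from 4500 nM to 28000 nM, the width reflecting that only one earlier step supports the expectation.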

Compound 4, half-maximal inhibitory concentration: 59300 nM
Estimate against measurement, compound 4: 5.4-fold (0.73 log units) below; measured number above the stated range.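

In this assay, hydroxy in place of hydrogen on an aromatic carbon moved the number the same way on both cores, and the new step is a 16-fold higher number from compound 3 to compound 4 (1.20 log units; beyond the scatter). The direction of the change carried from one core to the other, but its size did not: the same change on two cores in this assay, a 3.1-fold higher number (0.49 log units; beyond the scatter) from compound 1 to compound 2 and a 16-fold higher number (1.20 log units; beyond the scatter) from compound 3 to compound 4, 5.1-fold (0.71 log units) apart, beyond the scatter of two such steps. These two pairs do not show which difference between the core of compound 1 and the core of compound 3 goes with the larger step, and two steps set no rule for other cores in the series.

Still open, as far as these compounds go, is whether a methoxy group or an amine at the same place would give a similar step on either core, which would help separate what belongs to hydroxy from what belongs to any group at that place. Also open, from the compounds shown here alone, is whether steps of these sizes would appear in any read-out other than this assay.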